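A Thiophene in Place of Chlorophenyl on an Oxadiazole Core

This account rests on a few compounds, and the source may have more. Where it says the series, first, only, none or still open, it means among the compounds named here.

Of the compounds shown here, three built on one shared core have been measured in a functional assay on CHO cells for agonist activity at Free fatty acid receptor 1 (Homo sapiens), read by FLIPR and calcium flux, in the presence of a further agent that is not named here; a higher number here means that more compound is needed for the effect, a lower number that less compound is needed. Compound 1 `O=C(O)CCc1ccc(OCc2ncc(-c3ccccc3)o2)cc1` gives 1600 nM in this assay. Compound 2 `O=C(O)CCc1ccc(OCc2nc(-c3ccccc3Cl)no2)cc1` gives 1200 nM. Compound 3 `O=C(O)CCc1ccc(OCc2coc(-c3cccc(F)c3)n2)cc1` gives 560 nM. Among these three numbers compound 2 holds the second highest; its nearest neighbour is compound 1, whose value lies within the usual scatter of it, so no order between those two can be claimed, while compound 3 stands furthest away, at a lower number that lies beyond the scatter.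

For the measured compounds named here, no pair among the measured compounds differs in a single place, so no measured step can guide the next move. Compound 4 `O=C(O)CCc1ccc(OCc2nc(-c3cccs3)no2)cc1` is derived from compound 2 by one change: thiophen-2-yl in place of 2-chlorophenyl on an aromatic carbon. Going by the values given here, with no comparable step to lean on, the expectation is a modest shift, most likely toward a somewhat higher number in this assay, and possibly none beyond the scatter at all. The step from compound 2 to compound 4 is estimated as a 1.3-fold higher number from compound 2 to compound 4 (0.10 log units; within the scatter). On that basis compound 4 is expected to give 1500 nM in this assay, with a range from 500 nM to 4500 nM.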

Compound 4, half-maximal effective concentration: 2570 nM
Beside the measured number, compound 4's estimate is 1.7-fold (0.23 log units) below it; low and high end bracket the measured number.
By their numbers in this assay, from the lowest: compound 3; then compounds 2, 1 and 4 (each within the scatter of the next, the first and the last beyond it).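

In this assay, for the compounds shown here, the change of 2-chlorophenyl to thiophen-2-yl gives a 2.1-fold higher number from compound 2 to compound 4 (0.33 log units; beyond the scatter), the first step that can be read in a single place. It shows that the aromatic carbon between two ring nitrogen atoms does not accept any aromatic group equally: on this core, the one-for-one exchange of a six-membered aromatic ring of carbon only for a five-membered aromatic ring with 1 hetero atom carries a cost that lies beyond the scatter, though a modest one. Nothing at hand explains why the number moves in this direction.

The change alters the ring size, removes the chlorine and brings in the sulfur all at once, so the compounds shown leave open which of these accounts for the step. Whether 2-methylphenyl would hold the number of compound 2, or whether pyridin-2-yl or thiophen-3-yl at the same carbon would recover what thiophen-2-yl gives up, remains an open question, as does how far this single step applies to the other cores in the series.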